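Adding One Hydroxy to Compound 2

A few compounds are considered here, and "the series" means these few. Any claim that something is new, unique, unknown or untested is made for them only; others in the source may bear on it.

Going by the values given here, only two compounds have been measured so far. In a functional assay on RAW264.7 cells (Mus musculus) for inhibition, read by Griess assay, with a stated time of 24 h (a higher number here means a weaker inhibitor, a lower number a stronger inhibitor), compound 1 `C=C1[C@@H](OC(C)=O)[C@@H](OC(=O)c2ccccc2)[C@@H](OC(C)=O)C(C)(C)[C@H]2O[C@](O)([C@H](C)C2=O)[C@@]2(OC(C)=O)C[C@@](C)(O)[C@H](OC(C)=O)[C@@H]2[C@H]1OC(C)=O` gives 50200 nM, while compound 2 `C=C1[C@H](OC(=O)c2ccccc2)[C@H]2[C@@H](OC(C)=O)[C@](C)(O)C[C@]2(OC(C)=O)C(=O)[C@@H](C)/C=C/C(C)(C)C(=O)[C@H](O)[C@H]1OC(=O)c1ccccc1` gives 14500 nM. Compound 2 therefore has the lower of the two numbers, making it the stronger inhibitor, and the gap lies beyond the usual scatter. These two compounds differ in more than one place, so their gap cannot be tied to any single change.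

Compound 3 `C=C1[C@H](OC(=O)c2ccccc2)[C@H]2[C@@H](OC(C)=O)[C@](C)(O)[C@@H](O)[C@]2(OC(C)=O)C(=O)[C@@H](C)/C=C/C(C)(C)C(=O)[C@H](O)[C@H]1OC(=O)c1ccccc1` differs from compound 2 in one place: hydroxy in place of hydrogen on a saturated ring carbon. This is hydroxy in place of hydrogen on a saturated ring carbon. Among the compounds with values here, no measured pair shows the effect of this change, so the expectation is loose. No shift beyond the scatter is expected in this assay, and the estimated step is a 1.2-fold higher number from compound 2 to compound 3 (0.09 log units; within the scatter). For compound 3 the estimated value is 18000 nM, with an expected range from 6500 nM to 45000 nM.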

Compound 3, half-maximal inhibitory concentration: 46500 nM
Compound 3: middle estimate off by 2.6-fold (0.41 log units), on the low side; the measured number lies above the stated range.
By their numbers in this assay, from the lowest: compound 2; then compounds 3 and 1 (each within the scatter of the next).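

In this assay this saturated ring carbon of the five-membered ring turns out not to be indifferent to substitution: hydroxy in place of hydrogen gives a 3.2-fold higher number from compound 2 to compound 3 (0.51 log units; beyond the scatter) and so a weaker inhibitor. Going by these compounds alone, this is the first change in a single place that can be read here, but it is one pair on one core, so it describes this step and sets no general rule for the position. Nothing available gives a reason for this step.

The compounds shown leave open whether the weakening belongs to the hydroxy itself or would follow any group on this carbon, which a methoxy or an amine in the same place could separate. They also leave open whether the same step would appear on the core of compound 1.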